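The compounds below may be only part of what the source reports. "The series", "measured", "known", "first", "only" and "open" are said of these compounds alone.

Measured in a functional assay on MCF7 cells (Homo sapiens) for inhibition, with a stated time of 48 h; on this read-out lower numbers stand for stronger inhibition and higher numbers for weaker inhibition:
- compound 1 `COc1cc(Sc2c[nH]c3ccc(F)cc23)cc(OC)c1OC`: 160 nM
- compound 2 `COc1cc(Sc2c[nH]c3ccc([N+](=O)[O-])cc23)cc(OC)c1OC`: 560 nM

Compound 2, at 560 nM, holds the higher of the two numbers. Compound 3 `COc1ccc2[nH]cc(Sc3cc(OC)c(OC)c(OC)c3)c2c1` differs from it by methoxy in place of nitro on an aromatic carbon. Going by the values given here, the one measured step, a 3.5-fold higher number from compound 1 to compound 2 (0.54 log units; beyond the scatter), put nitro in place of fluoro and was modest but beyond the scatter. Among the compounds with values here, no methoxy compound has been measured, so this step bears only on the loss of nitro. A step of similar size towards a lower number is therefore expected in this assay. The estimate implies an expected 2.5-fold lower number from compound 2 to compound 3 (0.41 log units; beyond the scatter). Compound 3 is expected at 220 nM, within an estimated range of 70 nM to 650 nM.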

Compound 3, half-maximal inhibitory concentration: 22 nM
Compound 3: middle estimate off by 10-fold (1.00 log units), on the high side; measured number below the stated range.
By their numbers in this assay, from the lowest: compound 3; then compound 1; then compound 2.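

At this place on the aromatic ring, methoxy gives the lowest number of the three in this assay, with a large step from nitro (a 25-fold lower number from compound 2 to compound 3 (1.41 log units; beyond the scatter)) and a modest one from fluoro (a 7.3-fold lower number from compound 1 to compound 3 (0.86 log units; beyond the scatter)). The earlier pair showed only that nitro stood above fluoro, whereas methoxy shows that a change here can also carry the number well below fluoro. Nothing available explains this order. The compounds shown leave open whether ethoxy, a longer chain, or an amine would keep the number of compound 3 at this place.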